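This account rests on a few compounds, and the source may have more. Where it says the series, first, only, none or still open, it means among the compounds named here.

Measured compounds:
compound 1, `COc1cc2c(Nc3ccc4sc(C(=O)Nc5c(C)cccc5Cl)cc4c3)ncnc2cc1OCCCN1CCCCC1C`, 84.2%
compound 2, `CCN(CC)CCCOc1cc2ncnc(Nc3ccc4sc(C(=O)Nc5c(C)cccc5Cl)cc4c3)c2cc1OC`, 72.5%
compound 3, `COc1cc2c(Nc3ccc4sc(C(=O)Nc5c(C)cccc5Cl)cc4c3)ncnc2cc1OCCCN1CCCCC1`, 71.8%

All three were tested in a functional assay on K562 cells (Homo sapiens) for inhibition, read by MTT assay and WST assay, with a stated time of 72 h, tested at 10 uM; on this read-out lower numbers stand for less inhibition of growth and higher numbers for more inhibition of growth at the one concentration tested. Compound 3 stands lowest of the three numbers: compound 2 lies a number 0.7 percentage points lower from compound 2 to compound 3 (within the scatter), which is within the scatter, while compound 1 lies furthest, the step being a number 12.4 percentage points lower from compound 1 to compound 3 (beyond the scatter). The other step, a number 11.7 percentage points lower from compound 1 to compound 2 (beyond the scatter), is likewise modest.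

Compound 4, `COc1cc2c(Nc3ccc4sc(C(=O)Nc5c(C)cccc5Cl)cc4c3)ncnc2cc1OCCCN1CCN(C)CC1`, has not yet been measured. It differs from compound 3 in one place: 4-methylpiperazin-1-yl in place of piperidin-1-yl on a saturated chain carbon, three bonds along the chain from an oxygen on an aromatic ring. Among the measured compounds shown here, two measured steps bear on this position on the chain. From compound 2 to compound 3 the exchange of one amine for another at this position gave a number 0.7 percentage points lower from compound 2 to compound 3 (within the scatter), within the scatter. From compound 1 to compound 3 the loss of a methyl on the saturated ring carbon gave a number 12.4 percentage points lower from compound 1 to compound 3 (beyond the scatter), a modest drop. For the measured compounds named here, no measured compound carries a 4-methylpiperazin-1-yl, so there is no direct precedent for the ring with two hetero atoms. Taking the amine swap between compound 2 and compound 3 as the closest guide, the expected step from compound 3 to compound 4 is a number 1.8 percentage points lower from compound 3 to compound 4 (within the scatter), not beyond the scatter. Compound 4 is therefore estimated at 70%, with a range from 55% to 85%.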

Compound 4, percent growth inhibition at one concentration: 51.2%
Compound 4: the middle estimate sits 18.8 percentage points above what was measured, outside the stated range (below it).
By their numbers in this assay, from the lowest: compound 4; then compounds 3 and 2 (each within the scatter of the next); then compound 1.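

In this assay this place on the chain turns out not to be indifferent to the amine it carries: the earlier exchange of diethylamino for piperidin-1-yl stayed within the scatter, yet 4-methylpiperazin-1-yl in place of piperidin-1-yl gives a number 20.6 percentage points lower from compound 3 to compound 4 (beyond the scatter) and in place of diethylamino gives a number 21.3 percentage points lower from compound 2 to compound 4 (beyond the scatter). Against 2-methylpiperidin-1-yl the same group gives a number 33 percentage points lower from compound 1 to compound 4 (beyond the scatter), the only large step in the set, so compound 4 stands lowest, with its steps to all three others beyond the scatter, and the amines at this position span a wider range than the first three compounds showed. Nothing at hand says why the number falls with this ring.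

The compounds shown leave open whether the lower number goes with the second ring nitrogen itself or with the methyl of the 4-methylpiperazin-1-yl, since the two enter together here. A piperazin-1-yl or a morpholin-4-yl on the same 3-carbon propyl chain would separate these two, and would show whether a ring oxygen in that place follows the piperidin-1-yl or the 4-methylpiperazin-1-yl.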